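Cyclopentyl on the low end of the series

The source may report more compounds than this note shows. Statements on the series, on what has been measured and on what is new or still open speak of the compounds shown alone.

Measured so far in an ADME assay on microsomes from liver (Homo sapiens) for metabolic stability, with a stated time of 60 min, tested at 1 uM; on this read-out higher numbers stand for a more stable compound and lower numbers for a less stable compound
compound 1 `COc1cc(-c2cnn3cc(OC)c(C4CCOC4)nc23)ccn1` gives 29%
compound 2 `COc1cnc2c(-c3ccnc(OC)c3)cnn2c1` gives 2%

Within the data shown here, compound 2 holds the lower of the two numbers, and compound 1 is its only neighbour, with the gap beyond the scatter. Compound 3 `COc1cc(-c2cnn3cc(OC)c(C4CCCC4)nc23)ccn1` is still unmeasured and differs from compound 2 by cyclopentyl in place of hydrogen on an aromatic carbon on the same aromatic carbon that carries oxolan-3-yl in compound 1.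

Among the measured compounds shown here, one measured step bears on this change: a number 27 percentage points lower from compound 1 to compound 2 (beyond the scatter) when hydrogen takes the place of oxolan-3-yl. Read in reverse, this single pair links a ring at that carbon with the higher number. For the measured compounds named here, no measured compound compares cyclopentyl directly with oxolan-3-yl, so the size of the step carries over only loosely. An upward move is expected, and the estimated step runs a number 14 percentage points higher from compound 2 to compound 3 (beyond the scatter) and may fall short of the measured one. In this assay the expected value of compound 3 is 16% with an estimated range from 4% to 35% for repeated measurements.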

Compound 3, percent of the compound remaining: 32%
The estimate for compound 3 lay 16 percentage points below the measured number; the range from low to high includes it.
By their numbers in this assay, from the lowest: compound 2; then compounds 1 and 3 (each within the scatter of the next).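

In this assay, the step of a number 30 percentage points higher from compound 2 to compound 3 (beyond the scatter) comes with cyclopentyl in place of hydrogen on the aromatic carbon next to the ring nitrogen, so a second five-membered non-aromatic ring at this carbon now stands apart from hydrogen, and the link no longer rests on oxolan-3-yl alone. The direct comparison of the two rings reads a number 3 percentage points higher from compound 1 to compound 3 (within the scatter), so on this read-out compound 1 and compound 3 cannot be told apart, and a ring of carbon only and oxolan-3-yl sit on the same level at this carbon. No supporting data accompany these numbers, and the reason for the gap to hydrogen stays unexplained.

Among these compounds, at this carbon the series so far holds only hydrogen and two five-membered non-aromatic rings, so it remains open whether a ring is needed at all or whether an open chain such as n-butyl would serve as well. Also open, from the compounds shown here alone, is how a smaller group such as methyl, or an amine such as piperidin-1-yl, would compare with cyclopentyl in this assay.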